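The compounds below may be only part of what the source reports. "The series", "measured", "known", "first", "only" and "open" are said of these compounds alone.

Compound 1 `C[Si](C)(C)CCOCn1c(CC(O)COCc2ccccc2)cc(=O)[nH]c1=O`: in a functional assay on MCF7 cells (Homo sapiens) for antiproliferative activity, read by MTT assay, with a stated time of 72 h (a higher number here means a weaker inhibitor, a lower number a stronger inhibitor), compound 1 gives > 100000 nM, which is a limit of the assay rather than a number.
Compound 2 `C[Si](C)(C)CCOCn1c(CC(O)CO)cc(=O)[nH]c1=O`: in this assay compound 2 gives > 100000 nM, also a limit.
Compound 3 `COCn1c(CC(O)COCc2ccccc2)c(C)c(=O)[nH]c1=O`: in this assay compound 3 gives > 100000 nM, again a limit.

From compound 1 to compound 2 the change is hydrogen in place of benzyl on an oxygen on a saturated carbon. The resulting step that the two limits leave unreadable from compound 1 to compound 2 cannot be read, since both values sit at the limit of > 100000 nM in this assay, at which 3 of the 3 values shown sit. Compound 4 `COCn1c(CC(O)CO)c(C)c(=O)[nH]c1=O` has not yet been measured; it arises from compound 3 by the same change, (hydrogen in place of benzyl on an oxygen on a saturated carbon). The difference between the two cores is not broken down here. Compound 4 is expected to show a step that the limit leaves unreadable from compound 3 to compound 4, an expectation resting on the unreadable step that the two limits leave unreadable from compound 1 to compound 2 and on compound 3 sitting at the limit of > 100000 nM in this assay, at which 3 of the 3 values shown sit. For compound 4 the estimate in this assay is 150000 nM, within a range from 100000 nM to 400000 nM.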

Compound 4, half-maximal inhibitory concentration: > 100000 nM
Compound 4: a limit, no number; the forecaster's own chance of this, stated with the estimate: 90%; the middle value is on the limit's open side.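

No step can be read from compound 3 to compound 4, as both values are limits of the assay rather than numbers: the limit of > 100000 nM in this assay, at which 4 of the 4 values shown sit.

The compounds shown leave open whether hydrogen in place of benzyl changes activity at all in this assay.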